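The compounds below may be only part of what the source reports. "The series", "measured", "known", "first", "only" and "open" are said of these compounds alone.

Working notes on the series in an ADME assay on Vero cells (Chlorocebus sabaeus) for cytotoxicity; on this read-out higher numbers stand for weaker inhibition and lower numbers for stronger inhibition. Three compounds of one shared core carry a measurement. Compound 1 `O=C1c2nccnc2C(=O)N1c1ccccc1` gives 71000 nM in this assay. Compound 2 `O=C1c2nccnc2C(=O)N1c1ccc(Cl)cc1` gives 86000 nM. Compound 3 `O=C1c2nccnc2C(=O)N1Cc1ccc(Cl)cc1` gives 88000 nM. Among the compounds with values here, the one counted step between measured compounds, a 1.2-fold lower number from compound 2 to compound 1 (0.08 log units; within the scatter), corresponds to the change (hydrogen in place of chloro on an aromatic carbon). The difference between the core of compound 2 and the core of compound 3 is not broken down here; their two values lie within the scatter of each other, and the value of compound 1 is within the scatter of both as well.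

Compound 4 `O=C1c2nccnc2C(=O)N1Cc1ccccc1` awaits measurement in this assay. It differs from compound 3 by hydrogen in place of chloro on an aromatic carbon, the same change as from compound 2 to compound 1, with the place described in the same words for both pairs. Within the data shown here, the expected step of a 1.2-fold lower number from compound 3 to compound 4 (0.07 log units; within the scatter) rests on the single earlier step of a 1.2-fold lower number from compound 2 to compound 1 (0.08 log units; within the scatter), which lay within the scatter. Compound 4 is accordingly estimated at 75000 nM, with a range from 40000 nM to 150000 nM expected.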

Compound 4, half-maximal inhibitory concentration: > 100000 nM
Compound 4 was reported as a limit (the forecaster's own chance of this, stated with the estimate: 10%); middle value at least 1.3-fold (0.12 log units) from the limit.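

In this assay compound 4 gives > 100000 nM, which is a limit of the assay and not a number. On these data alone, that limit allows only a floor for the new step, an at least 1.1-fold higher number from compound 3 to compound 4 (0.05 log units; that floor lies within the scatter), and this step can be set beside the earlier one for hydrogen in place of chloro on an aromatic carbon: the same change on two cores in this assay, a 1.2-fold lower number (0.08 log units; within the scatter) from compound 2 to compound 1 and an at least 1.1-fold higher number (0.05 log units; that floor lies within the scatter) from compound 3 to compound 4; the limit leaves it open whether they differ The two cores therefore give no evidence that the change behaves differently from one to the other, but they do not show that it carries over unchanged either, since the true size of the step on the core of compound 3 remains unknown.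

The compounds shown carry only hydrogen or chloro at this place on the six-membered aromatic ring of carbon only, which leaves open how an amine, a nitrile or a carboxylic acid there would read in this assay. Also open, as far as these compounds go, is whether a longer chain on the shared core would give a number clear of the limit.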